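This account rests on a few compounds, and the source may have more. Where it says the series, first, only, none or still open, it means among the compounds named here.

Compound 1 `Cn1ncc2c(NC(=O)NCc3cc(C(F)(F)F)nn3-c3cccc(Cl)c3)cccc21` and compound 2 `Cn1ncc2c(NC(=O)NCc3cc(C(F)(F)F)nn3-c3cccc(F)c3)cccc21` share one core, while compound 3 `CC(C)(C)c1cc(CNC(=O)Nc2cccc3[nH]ncc23)n(-c2ccc(F)c(F)c2)n1` is built on another; how the two cores differ is not broken down here. In an assay on CHO-K1 cells for antagonist activity at transient receptor potential cation channel subfamily V member 1 (Homo sapiens), read by FLIPR and calcium flux, with a stated time of 6 min (a lower number here means a stronger inhibitor, a higher number a weaker inhibitor), compound 1 gives 2.3 nM, compound 2 gives 7 nM, and compound 3 gives 0.5 nM, the lowest of the three numbers. The change chloro in place of fluoro on an aromatic carbon produced a 3.0-fold lower number from compound 2 to compound 1 (0.48 log units; beyond the scatter). Compound 4 `CC(C)(C)c1cc(CNC(=O)Nc2cccc3[nH]ncc23)n(-c2ccc(F)c(Cl)c2)n1` carries the same kind of change, (chloro in place of fluoro on an aromatic carbon), but at its place the aromatic carbon is also ortho to a fluoro group, so the two changes count as the same kind rather than the same. The expected step in this assay is a 2.0-fold lower number from compound 3 to compound 4 (0.30 log units; within the scatter). That expectation rests on a 3.0-fold lower number from compound 2 to compound 1 (0.48 log units; beyond the scatter), even though that pair sits on the other core. Compound 4 is therefore expected to give about 0.25 nM in this assay, between 0.1 nM and 0.7 nM.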

Compound 4, inhibition constant: 0.5 nM
Compound 4: the middle estimate sits 2.0-fold (0.30 log units) below what was measured; the measured number falls inside the stated range.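

In this assay, chloro in place of fluoro on an aromatic carbon gives no change at the digits printed from compound 3 to compound 4 (within the scatter). For the compounds shown here, the size of this step did not carry over from one core to the other: the same change on two cores in this assay, a 3.0-fold lower number (0.48 log units; beyond the scatter) from compound 2 to compound 1 and no change at the digits printed (within the scatter) from compound 3 to compound 4, 3.0-fold (0.48 log units) apart, beyond the scatter of two such steps With only one pair on each core, and with the changed carbon in compound 4 also ortho to a fluoro group, this does not show which difference between the two pairs accounts for the gap, nor how the change would behave elsewhere.

On these data alone, whether the step on the core of compound 3 would differ without that fluoro group remains open. So does how a bromo or methoxy group at the same place would read in this assay.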